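Moving a fluorine on the sulfonyl-linked ring: expected clearance

The source may hold more compounds than are shown below. What is called first, only, known or untested is meant among the compounds shown, and "the series" means these compounds.

Measured compounds:
- Compound 1, `COc1cccc(-c2c(S(=O)(=O)c3cc(F)cc(F)c3)cnc3cc(F)ccc23)c1`, gives 1.81 mL/min in an ADME assay on microsomes from liver (Homo sapiens) for metabolic stability, tested at 2.5 uM; on this read-out lower numbers stand for slow clearance and higher numbers for fast clearance.
- Compound 2, `O=S(=O)(c1ccc(F)cc1)c1cnc2c(F)cccc2c1-c1cccc(F)c1`, gives 1.56 mL/min in this assay.
- Compound 3, `COc1cccc(-c2c(S(=O)(=O)c3ccc(F)cc3)cnc3c(F)cccc23)c1`, gives 2.23 mL/min in this assay.

Compound 2 has the lowest of the three numbers, yet compound 1 and compound 3 sit within the scatter of it, so the three cannot be told apart. Compound 4, `O=S(=O)(c1cccc(F)c1)c1cnc2c(F)cccc2c1-c1cccc(F)c1`, is not yet measured; it differs from compound 2 in one place: 3-fluorophenyl in place of 4-fluorophenyl on a sulfonyl sulfur. Going by the values given here, no measured step changes this ring in the same way. Among the compounds with values here, the only step available, a 1.4-fold higher number from compound 2 to compound 3 (0.16 log units; within the scatter), concerns a different ring and stays within the scatter. With nothing pointing either way, the step from compound 2 to compound 4 is expected to be a 1.1-fold higher number from compound 2 to compound 4 (0.04 log units; within the scatter). Compound 4 is therefore estimated at 1.7 mL/min, between 0.9 mL/min and 3.2 mL/min.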

Compound 4, intrinsic clearance in a liver preparation (reported as CLH), per the amount of preparation that the assay uses: 1.14 mL/min
For compound 4 the middle estimate is 1.5-fold (0.17 log units) above the measured one, and the stated range covers the measured number.
By their numbers in this assay, from the lowest: compounds 4, 2, 1 and 3 (each within the scatter of the next).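

In this assay, going by these compounds alone, the first measured change on the sulfonyl-linked ring, 3-fluorophenyl in place of 4-fluorophenyl on a sulfonyl sulfur, gives a 1.4-fold lower number from compound 2 to compound 4 (0.14 log units; within the scatter) and so stays inside the usual scatter. In this one pair, moving the fluorine on this ring brings no clear change in clearance. No measurement here explains the result.

As far as these compounds go, whether the same move would read alike in compound 3 remains open. So does the effect of an amine or a carboxylic acid in place of the fluorine on this ring.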